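A few compounds are considered here, and "the series" means these few. Any claim that something is new, unique, unknown or untested is made for them only; others in the source may bear on it.

In a functional assay on DU-145 cells (Homo sapiens) for cytotoxicity, read by MTT assay, with a stated time of 48 h (a higher number here means a weaker inhibitor, a lower number a stronger inhibitor), compound 1 (`COc1ccc(/C=C/C(=O)/C=C/c2cc3ccccc3nc2Cl)c(OC)c1`) gives > 10000 nM, which is a limit and not a number. Compound 2 (`COc1cc(OC)c(/C=C/C(=O)/C=C/c2cc3ccccc3nc2Cl)c(OC)c1`) gives > 10000 nM, which is likewise a limit. For the measured compounds named here, compound 2 therefore has no numerical position, and the only other value is also a limit: the limit of > 10000 nM in this assay, at which 2 of the 2 values shown sit.

Compound 3 (`COc1cc(OC)c(/C=C/C(=O)/C=C/c2cc3ccccc3nc2Oc2ccccc2)c(OC)c1`) has phenoxy in place of chloro on an aromatic carbon, next to the ring nitrogen: phenoxy in place of chloro on an aromatic carbon. Going by the values given here, the single measured step, a step that the two limits leave unreadable from compound 1 to compound 2, concerns methoxy in place of hydrogen on an aromatic carbon. Among the compounds with values here, it has no readable size and does not touch the chloro position, so no measured step bears directly on this change.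

Within the data shown here, no step of known size can be carried over to this assay. A modest move toward stronger inhibition is expected, though another limit remains more likely than not. The step expected is an at least 1.1-fold lower number from compound 2 to compound 3 (0.04 log units; that floor lies within the scatter), and this is only a rough estimate. For compound 3 the estimated value is 9000 nM, with an expected range of 2500 nM to 30000 nM.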

Compound 3, half-maximal inhibitory concentration: > 10000 nM
Compound 3: a limit, no number (the forecaster's own chance of this, stated with the estimate: 55%); middle value at least 1.1-fold (0.04 log units) from the limit.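

In this assay, compound 3 gives > 10000 nM, which is a limit and not a number. Compound 2 also stands only at a limit, so no step can be read between compound 2 and compound 3. The compounds shown leave open whether phenoxy in place of chloro changes the activity at all, and in which direction.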